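The source may report more compounds than this note shows. Statements on the series, on what has been measured and on what is new or still open speak of the compounds shown alone.

Values in a physicochemical assay for solubility, in phosphate buffer, measured as kinetic solubility, at pH 7.4 (on this read-out lower numbers stand for lower solubility and higher numbers for higher solubility), each one a limit of the assay:
Compound 1 `Cc1ccccc1-c1nc(CN2CCC(C(=O)NCCCN3CCC(C)(C)CC3)CC2)c(C)o1`: > 69 ug/mL
Compound 2 `Cc1oc(-c2ccc(Cl)cc2)nc1CN1CCC(C(=O)NCCCN2C[C@H](C)C[C@H](C)C2)CC1`: > 72 ug/mL
Compound 3 `Cc1oc(-c2c(Cl)cccc2Cl)nc1CN1CCC(C(=O)NCCCN2C[C@H](C)C[C@H](C)C2)CC1`: > 77 ug/mL

Compound 1 gives no number, only a limit: it stands at the limit of > 69 ug/mL in this assay, at which 1 of the 3 values shown sits. The unmeasured compound 4 `Cc1ccccc1-c1nc(CN2CCC(C(=O)NCCCN3CCCC(C(C)C)C3)CC2)c(C)o1` differs from it by a group of 9 heavy atoms (8 carbon, 1 nitrogen; one six-membered non-aromatic ring with 1 hetero atom) in place of a group of 8 heavy atoms (7 carbon, 1 nitrogen; one six-membered non-aromatic ring with 1 hetero atom), on a saturated chain carbon, three bonds along the chain from an amide-type nitrogen. Going by the values given here, the one measured step, a step that the two limits leave unreadable from compound 2 to compound 3, concerns a different place in the molecule, and its size cannot be read, so it gives no measure for this change. No step beyond the scatter is therefore expected in this assay. The expected step is a step that the limit leaves unreadable from compound 1 to compound 4. Compound 4 is expected at 72 ug/mL, with an estimated range from 45 ug/mL to 90 ug/mL.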

Compound 4, solubility: > 71 ug/mL
Compound 4: no number, only a limit; the forecaster's own chance of this, stated with the estimate: 75%; the middle value lies beyond the limit too.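

In this assay, going by these compounds alone, compound 1 and compound 4 each give only a limit, so no step between them can be read. The compounds shown leave open whether exchanging either group changes this read-out at all.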